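Swapping the aryl group on the piperidine nitrogen substituent

The source may report more compounds than this note shows. Statements on the series, on what has been measured and on what is new or still open speak of the compounds shown alone.

Measured compounds:
Compound 1, `Cn1cc(CN2CCC[C@H](OCc3cc(Cl)cc(Cl)c3)[C@@H]2c2ccccc2)cn1`, gives 110000 nM.
Compound 2, `O=C(O)c1cncc(CN2CCC[C@H](OCc3cc(Cl)cc(Cl)c3)[C@@H]2c2ccccc2)c1`, gives 117000 nM.
Compound 3, `COc1cc(C(=O)O)ccc1CN1CCC[C@H](OCc2cc(Cl)cc(Cl)c2)[C@@H]1c1ccccc1`, gives 62000 nM.

In an assay on isolated protein for activation of cGMP-dependent protein kinase 1 (Homo sapiens), read by ADP-Glo, with stated times of 120 min and 40 min (on this read-out higher numbers stand for an effect only at larger amounts of compound and lower numbers for an effect already at smaller amounts), compound 3 has the lowest of the three numbers, yet its separation from the others is within the scatter: a 1.8-fold lower number from compound 1 to compound 3 (0.25 log units; within the scatter) and a 1.9-fold lower number from compound 2 to compound 3 (0.28 log units; within the scatter). Compound 4, `Cn1ccnc1CN1CCC[C@H](OCc2cc(Cl)cc(Cl)c2)[C@@H]1c1ccccc1`, carries a further change at the same place: 1-methyl-1H-imidazol-2-yl in place of 4-carboxy-2-methoxyphenyl on a saturated chain carbon bound to an amine nitrogen in a ring. The two steps into compound 3 both varied the aryl group on that carbon and both stayed within the scatter, and the step of a 1.1-fold higher number from compound 1 to compound 2 (0.03 log units; within the scatter) did the same, so no step beyond the scatter is expected for compound 4. The expected step is a 1.4-fold higher number from compound 3 to compound 4 (0.14 log units; within the scatter). Compound 4 is therefore estimated at 85000 nM, between 30000 nM and 250000 nM.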

Compound 4, half-maximal effective concentration: 165000 nM
The estimate for compound 4 lay 1.9-fold (0.29 log units) below the measured number, within the range that was stated.
By their numbers in this assay, from the lowest: compounds 3, 1, 2 and 4 (each within the scatter of the next, the first and the last beyond it).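

In this assay, among these compounds, the step of a 2.7-fold higher number from compound 3 to compound 4 (0.43 log units; beyond the scatter) is the first at this position to lie beyond the scatter, so a change on a saturated chain carbon bound to an amine nitrogen in a ring can shift the number, though only modestly. The separation holds against compound 3 alone, since a 1.4-fold higher number from compound 2 to compound 4 (0.15 log units; within the scatter) and a 1.5-fold higher number from compound 1 to compound 4 (0.18 log units; within the scatter) both stay within the scatter. Nothing available explains this step.

From the compounds shown here alone, whether the carboxylic acid or the methoxy group in 4-carboxy-2-methoxyphenyl accounts for the gap stays open, as does how a phenyl ring bearing an aminomethyl group would compare with compound 3.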